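The compounds below may be only part of what the source reports. "The series", "measured", "known", "first", "only" and "open" are said of these compounds alone.

Three compounds have been measured in an assay on Sf9 cells for inhibition of protein deacetylase HDAC6 (Homo sapiens), read by fluorescence; a higher number here means a weaker inhibitor, a lower number a stronger inhibitor:
Compound 1, `O=C(NO)c1cc(F)c(Cn2nnc(-c3ccco3)n2)c(F)c1`, gives 3 nM.
Compound 2, `Cn1c(Sc2c(F)cc(C(=O)NO)cc2F)nnc1-c1cccnn1`, gives 13 nM.
Compound 3, `O=C(NO)c1ccc(Cn2nnc(-c3ccc(S(F)(F)(F)(F)F)cc3)n2)cc1`, gives 25 nM.

Compound 3 has the highest number of the three. Its gap to compound 2 falls within the scatter, so the two cannot be told apart; only compound 1, with a number beyond the scatter, is clearly the stronger inhibitor. Compound 4, `O=C(NO)c1ccc(Cn2nnc(-c3ccccc3)n2)cc1`, differs from compound 3 in one place: a hydrogen atom in place of a group of 6 heavy atoms (5 fluorine, 1 sulfur; no ring), on an aromatic carbon. Among the compounds with values here, no measured pair shows this change, so its effect is unknown. Such a change is expected to give at most a small shift in this assay, if anything toward a higher number. The estimate for compound 4 is 35 nM, between 10 nM and 120 nM. This estimate means a step of a 1.4-fold higher number from compound 3 to compound 4 (0.15 log units; within the scatter), expected to stay within the scatter.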

Compound 4, half-maximal inhibitory concentration: 3 nM
Beside the measured number, compound 4's estimate is 12-fold (1.07 log units) above it; measured number outside the range, below it.
By their numbers in this assay, from the lowest: compounds 1 and 4 (each within the scatter of the next); then compounds 2 and 3 (each within the scatter of the next).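

In this assay, replacing the group of 6 heavy atoms (5 fluorine, 1 sulfur) with a hydrogen atom on this aromatic carbon gives an 8.3-fold lower number from compound 3 to compound 4 (0.92 log units; beyond the scatter) and so a clearly stronger inhibitor. At this position, the large group therefore gives weaker inhibition than plain hydrogen. Nothing available explains this difference.

Only these two substituents can be compared here. As far as these compounds go, whether a fluorine atom, a methyl group or an amine at this position would behave more like the hydrogen atom or the large group remains open.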